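Swapping Methoxy for Chloro on a Benzylamine Side Chain

This account rests on a few compounds, and the source may have more. Where it says the series, first, only, none or still open, it means among the compounds named here.

Compound 1, `COc1cc(/C=C/c2nc(NC3CC3)c3sccc3n2)cc(OC)c1OC`: > 50000 nM
Compound 2, `COc1ccc(CNc2nc(/C=C/c3cc(OC)c(OC)c(OC)c3)nc3ccsc23)cc1`: > 50000 nM

Both measured compounds share one core and differ only at a nitrogen on the aromatic ring system. In an ADME assay on RAW264.7 cells (Mus musculus) for cytotoxicity, read by MTT assay (on this read-out higher numbers stand for weaker inhibition and lower numbers for stronger inhibition), compound 1 gives > 50000 nM, which is a limit of the assay rather than a number. Compound 2 gives > 50000 nM, again a limit. For the measured compounds named here, the one measured step, a step that the two limits leave unreadable from compound 1 to compound 2, therefore has no readable size, and the limit of > 50000 nM in this assay, at which 2 of the 2 values shown sit, shows where both values sit. Compound 2 thus stands at the limit, not at a measured number.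

Compound 3, `COc1cc(/C=C/c2nc(NCc3ccc(Cl)cc3)c3sccc3n2)cc(OC)c1OC`, differs from compound 2 by chloro in place of methoxy on an aromatic carbon. Going by the values given here, no measured step bears readably on this change, so no shift beyond the scatter can be foreseen in this assay. Compound 3 is expected to remain at the limit, with an estimate of 50000 nM, between 20000 nM and 100000 nM. The step this estimate implies, a number no higher from compound 2 to compound 3 (the limit leaves the size open), is expected to lie within the scatter.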

Compound 3, half-maximal inhibitory concentration: > 50000 nM
Compound 3: no number, only a limit; the forecaster's own chance of this, stated with the estimate: 85%; the middle value lies on the limit itself.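

In this assay compound 3 gives > 50000 nM, which is a limit and not a number. No step among compound 1, compound 2 and compound 3 can therefore be read: the limit of > 50000 nM in this assay, at which 3 of the 3 values shown sit.

Where the true values of these compounds lie, and whether 4-chlorobenzyl and 4-methoxybenzyl differ at all on this read-out, stays open.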